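The source may report more compounds than this note shows. Statements on the series, on what has been measured and on what is new or still open speak of the compounds shown alone.

Within the data shown here, in an ADME assay on HEK-293T cells (Homo sapiens) for cytotoxicity, read by luminescence and CellTiter-Glo, with a stated time of 24 h (a lower number here means that less compound is tolerated, a higher number that more compound is tolerated), compound 1 (`CCCNC(=O)C1CCN(C(=O)c2cc3ncsc3n2Cc2ccc(OC)cc2)CC1`) gives 42700 nM as the only exact number so far. Compound 2 (`CCCNC(=O)[C@@H]1C[C@H]2CCC[C@@H](C1)[C@@H]2NC(=O)c1cc2sc(Br)cc2n1Cc1ccc(OC)cc1`) reads > 100000 nM as a limit of the assay and not a number. Compound 3 (`CCCNC(=O)C1CCN(C(=O)c2cc3nc(Br)sc3n2Cc2ccc(OC)cc2)CC1`) departs from compound 1 by a single change (bromo in place of hydrogen on an aromatic carbon): bromo in place of hydrogen on an aromatic carbon. Among the measured compounds shown here, no measured step covers this change, so no shift beyond the scatter is expected in this assay and the estimated step is small (a 1.2-fold higher number from compound 1 to compound 3 (0.07 log units; within the scatter)). For compound 3 the expected value is 50000 nM within an estimated range of 20000 nM to 100000 nM in this measurement.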

Compound 3, half-maximal cytotoxic concentration: 46800 nM
The estimate for compound 3 lay 1.1-fold (0.03 log units) above the measured number; the measured number falls inside the stated range.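

In this assay, the step at this position reads a 1.1-fold higher number from compound 1 to compound 3 (0.04 log units; within the scatter), so bromo in place of hydrogen on an aromatic carbon, next to the ring nitrogen and next to the ring sulfur, leaves the reading within the scatter. This is the only step that can be read here, and compound 2 gives no comparison, since its reading is a limit and not a number: the limit of > 100000 nM in this assay, at which 1 of the 3 values shown sits.

From the compounds shown here alone, whether a different group on this same carbon, such as an amine or a carboxylic acid, would shift the reading beyond the scatter remains open.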